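Swapping fluorine for chlorine on the pendant phenyl ring

The compounds below may be only part of what the source reports. "The series", "measured", "known", "first", "only" and "open" are said of these compounds alone.

Two compounds share one core and differ only in the aryl group at the end of the sulfur-linked chain. Compound 1 `C#CCNC1CCc2c(SCCc3ccc(Br)cc3)cccc21` gives 85300 nM in an assay on isolated protein for inhibition of Amine oxidase [flavin-containing] B (Homo sapiens); on this read-out higher numbers stand for weaker inhibition and lower numbers for stronger inhibition. Compound 2 `C#CCNC1CCc2c(SCCc3ccc(F)c(F)c3)cccc21` gives 3240 nM in this assay, the lowest of the two numbers. Among the compounds with values here, the one measured step, a 26-fold lower number from compound 1 to compound 2 (1.42 log units; beyond the scatter), was large and beyond the scatter. Compound 3 `C#CCNC1CCc2c(SCCc3ccc(Cl)c(Cl)c3)cccc21` carries 3,4-dichlorophenyl in place of 3,4-difluorophenyl on a saturated chain carbon, two bonds along the chain from a sulfur. The measured step changed both the halogen and its pattern at once, so it bears only loosely on this change, where the pattern stays and only the halogen changes. Compound 3 is therefore expected to land close to compound 2, with the step of a 1.1-fold lower number from compound 2 to compound 3 (0.03 log units; within the scatter) not clearly beyond the scatter. The estimate for compound 3 in this assay is 3000 nM, ranging from 600 nM to 15000 nM.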

Compound 3, half-maximal inhibitory concentration: 3850 nM
Beside the measured number, compound 3's estimate is 1.3-fold (0.11 log units) below it; measured number inside the range.
By their numbers in this assay, from the lowest: compounds 2 and 3 (each within the scatter of the next); then compound 1.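

In this assay, the step with the substitution pattern held fixed gives a 1.2-fold higher number from compound 2 to compound 3 (0.07 log units; within the scatter), so 3,4-dichlorophenyl and 3,4-difluorophenyl cannot be told apart at this position, something the earlier pair could not show. The other new step, a 22-fold lower number from compound 1 to compound 3 (1.35 log units; beyond the scatter), shows that a second group with two halogens also stands well apart from the 4-bromophenyl group, while no available measurement explains either result.

The compounds shown leave open whether compound 1 stands apart for its bromine or for having a single halogen, and a 4-chlorophenyl or 3,4-dibromophenyl group would help separate the two. Also open, as far as these compounds go, is how a methoxy group on the ring, or a longer chain between the sulfur and the ring, would behave.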